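Swapping a Hydroxy for a Methylpiperazine on a Lipid Chain

The source may hold more compounds than are shown below. What is called first, only, known or untested is meant among the compounds shown, and "the series" means these compounds.

Compound 1 `CCCCCCCCCCCCCC[C@H](OCOC)[C@H](CO)NC(=O)OC(C)(C)C` carries a hydroxy on a saturated chain carbon, two bonds along the chain from an amide-type nitrogen. In a functional assay on MDA-MB-231 cells (Homo sapiens) for antiproliferative activity, read by sulforhodamine B assay, with a stated time of 48 h, tested at 10 uM (on this read-out lower numbers stand for less inhibition and higher numbers for more inhibition at the one concentration tested (going by the name of the read-out)), compound 1 gives -5.67%, the lowest of the three numbers measured. Compound 2 `CCCCCCCCCCCCCC[C@H](OCOC)[C@H](CN(CC)CC)NC(=O)OC(C)(C)C` gives 0.84% and compound 3 `CCCCCCCCCCCCCC[C@H](OCOC)[C@H](CN(CCCC)CCCC)NC(=O)OC(C)(C)C` gives 22.3%. Compound 4 `CCCCCCCCCCCCCC[C@H](OCOC)[C@H](CN1CCN(C)CC1)NC(=O)OC(C)(C)C` differs from compound 1 by 4-methylpiperazin-1-yl in place of hydroxy on a saturated chain carbon, two bonds along the chain from an amide-type nitrogen. The measured steps that bear on this both replace the same hydroxy with an amine: a number 6.5 percentage points higher from compound 1 to compound 2 (within the scatter), whereas a number 28 percentage points higher from compound 1 to compound 3 (beyond the scatter); likewise a number 21.5 percentage points higher from compound 2 to compound 3 (beyond the scatter). For the measured compounds named here, no measured compound carries the amine within a ring. A small rise is expected, a number 13.7 percentage points higher from compound 1 to compound 4 (beyond the scatter). Compound 4 is estimated at 8%, within -10% to 30%.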

Compound 4, a percentage reported as inhibition, at one concentration (the size of the read-out at that concentration, not a potency): 24%
Compound 4: the middle estimate sits 16 percentage points below what was measured; the measured number falls inside the stated range.
By their numbers in this assay, from the lowest: compounds 1 and 2 (each within the scatter of the next); then compounds 3 and 4 (each within the scatter of the next).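

The ring amine reaches what only the dibutylamino group had reached so far: 4-methylpiperazin-1-yl in place of hydroxy gives a number 29.7 percentage points higher from compound 1 to compound 4 (beyond the scatter) and, against the diethylamino group, a number 23.2 percentage points higher from compound 2 to compound 4 (beyond the scatter) on the same saturated chain carbon. Against the dibutylamino group the change is a number 1.7 percentage points higher from compound 3 to compound 4 (within the scatter) and so shows no real difference, which means an amine here need not carry two butyl chains to reach this level of inhibition. Nothing available explains why these two different amines land together.

On these data alone, what piperidin-1-yl, morpholin-4-yl or a piperazin-1-yl without the methyl would give at this place stays open, and with it whether the second ring nitrogen or the methyl matters at all.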